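The source may hold more compounds than are shown below. What is called first, only, known or untested is meant among the compounds shown, and "the series" means these compounds.

Going by the values given here, compound 1 `COc1cc(/C=C/C(=O)c2cccc(-n3cc(-c4ccc(Cl)cc4)[nH]c3=O)c2)cc(OC)c1OC` gives 8880 nM in a functional assay on UACC-62 cells (Homo sapiens) for inhibition (on this read-out lower numbers stand for stronger inhibition of growth and higher numbers for weaker inhibition of growth), the highest number among the three compounds measured so far. Compound 2 `COc1cc(/C=C/C(=O)c2cccc(-n3cc(-c4ccccc4)[nH]c3=O)c2)ccc1O` gives 2010 nM and compound 3 `O=C(/C=C/c1cccc(O)c1)c1cccc(-n2cc(-c3ccccc3)[nH]c2=O)c1` gives 3650 nM in this assay. Among the compounds with values here, the only measured step changing a single place is a 1.8-fold higher number from compound 2 to compound 3 (0.26 log units; within the scatter); it alters the chain end rather than the ring on the shared core, so it does not bear directly on the change at hand. Compound 4 `COc1cc(/C=C/C(=O)c2cccc(-n3cc(-c4ccccc4)[nH]c3=O)c2)cc(OC)c1OC` differs from compound 1 by hydrogen in place of chloro on an aromatic carbon. Compounds 2 and 3 carry the same unsubstituted phenyl as compound 4 and both give lower numbers than compound 1, though their chain ends differ as well. A modest downward step is therefore expected, a 1.8-fold lower number from compound 1 to compound 4 (0.25 log units; within the scatter). For compound 4 the estimate is 5000 nM, between 2000 nM and 12000 nM.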

Compound 4, concentration for 50% growth inhibition: 1520 nM
For compound 4 the middle estimate is 3.3-fold (0.52 log units) above the measured one, outside the stated range (below it).
By their numbers in this assay, from the lowest: compounds 4, 2 and 3 (each within the scatter of the next, the first and the last beyond it); then compound 1.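

Going from 4-chlorophenyl to phenyl, with nothing else altered, gives a 5.8-fold lower number from compound 1 to compound 4 (0.77 log units; beyond the scatter) in this assay. Going by these compounds alone, this is the first direct reading at this ring position, since the earlier measured step changed only the chain end, and it shows that hydrogen here gives clearly stronger growth inhibition than chloro. Nothing available explains this difference.

As far as these compounds go, whether a fluoro or an amine at this position would give a number closer to compound 4 or to compound 1 remains open. Also open, from the compounds shown here alone, is whether chloro would raise the number with the chain ends of compound 2 and compound 3.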